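Swapping the Aryl Piperazine for an Ethyl Group

The source may hold more compounds than are shown below. What is called first, only, known or untested is meant among the compounds shown, and "the series" means these compounds.

Measured compounds:
- compound 1, `CC(C)(C)c1ccc(-c2nnc(SCCCN3CCN(c4ccccc4)CC3)[nH]2)cc1`: 97600 nM
- compound 2, `Cc1ccc(-c2nnc(SCCCN3CCN(c4cccc(Cl)c4)CC3)[nH]2)cc1`: > 300000 nM

In a functional assay on THP-1 cells (Homo sapiens) for cytotoxicity, read by MTT assay, with a stated time of 24 h (on this read-out lower numbers stand for stronger inhibition and higher numbers for weaker inhibition), compound 1 gives 97600 nM. For compound 2 this assay reports only a limit, > 300000 nM, so no exact number is known for it; it stands at the weak end of what is shown, at the limit described by the limit of > 300000 nM in this assay, at which 1 of the 2 values shown sits. Compound 3, `CCN1CCN(CCCSc2nnc(-c3ccc(C)cc3)[nH]2)CC1`, differs from compound 2 in one place: ethyl in place of 3-chlorophenyl on an amine nitrogen in a ring. Going by the values given here, no measured pair of compounds shares this kind of change, so its size cannot be read from the data. Both measured compounds show weak inhibition in this assay, and the change trades an aromatic ring for a short chain at the ring nitrogen. Compound 3 is expected to remain weak, with a step of an at least 1.2-fold lower number from compound 2 to compound 3 (0.07 log units; that floor lies within the scatter) expected to lie within the scatter. The estimate for compound 3 is 250000 nM, ranging from 90000 nM to 700000 nM, with a fair chance that only a limit is reported again.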

Compound 3, half-maximal inhibitory concentration: > 300000 nM
Compound 3 ended at the assay's limit (the forecaster's own chance of this, stated with the estimate: 55%); middle value at least 1.2-fold (0.07 log units) from the limit.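

Compound 2 and compound 3 are each reported in this assay only as a limit, not as an exact number, so no step can be read between them: the limit of > 300000 nM in this assay, at which 2 of the 3 values shown sit.

The compounds shown leave open whether ethyl in place of 3-chlorophenyl on an amine nitrogen in a ring changes the read-out at all, and in which direction.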